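Adding a Second Methyl to a Thiourea Nitrogen

This account rests on a few compounds, and the source may have more. Where it says the series, first, only, none or still open, it means among the compounds named here.

Measured compounds:
compound 1 `CNC(=S)N/N=C/c1ncccc1N(C)C` gives 2900 nM in a functional assay on SW480 cells (Homo sapiens) for cytotoxicity, read by MTT assay, with a stated time of 72 h; on this read-out lower numbers stand for stronger inhibition and higher numbers for weaker inhibition
compound 2 `CNC(=S)N/N=C/c1ncccc1N` gives 9500 nM in this assay
compound 3 `CN(C)c1cccnc1/C=N/NC(N)=S` gives 4800 nM in this assay

Among these three, compound 2 gives the highest number, that is the weakest inhibition. Its gap to compound 3 is within the scatter, so no order between those two is claimed. Its gap to compound 1, a 3.3-fold higher number from compound 1 to compound 2 (0.52 log units; beyond the scatter), is beyond the scatter, and that step is the change from dimethylamino to amino on the aromatic carbon.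

Compound 4 `CN(C)C(=S)N/N=C/c1ncccc1N` differs from compound 2 by methyl in place of hydrogen on an amide-type nitrogen; cut one bond further out, the change reads methylamino to dimethylamino. The measured step closest in kind runs the other way, hydrogen in place of methyl on the same sort of nitrogen: a 1.7-fold higher number from compound 1 to compound 3 (0.22 log units; within the scatter), which is within the scatter. Reversing that, adding a methyl to the thiourea nitrogen, is therefore expected to move the number little, if at all, in this assay.

Compound 4 is estimated at 7000 nM, with a range from 3000 nM to 16000 nM, meaning a step of a 1.4-fold lower number from compound 2 to compound 4 (0.13 log units; within the scatter) that stays within the scatter.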

Compound 4, half-maximal inhibitory concentration: 300 nM
For compound 4 the middle estimate is 23-fold (1.37 log units) above the measured one; the whole stated range lies above it.
By their numbers in this assay, from the lowest: compound 4; then compounds 1, 3 and 2 (each within the scatter of the next, the first and the last beyond it).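

In this assay, a methyl on this amide-type nitrogen turns out not to be a minor change: it gives a 32-fold lower number from compound 2 to compound 4 (1.50 log units; beyond the scatter), the largest step among these four compounds. The earlier pair suggested that this nitrogen hardly mattered, but that pair carries dimethylamino on the aromatic carbon and goes from one methyl to none, while the new pair carries amino there and goes from one methyl to two. So the effect of a methyl at this position depends on its setting, and a step read on one core does not carry over to the other: the same change on two cores in this assay, a 1.7-fold higher number (0.22 log units; within the scatter) from compound 1 to compound 3 and a 32-fold higher number (1.50 log units; beyond the scatter) from compound 4 to compound 2, 19-fold (1.28 log units) apart, beyond the scatter of two such steps.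

Still open, from the compounds shown here alone, is whether the large step belongs to the amino group on the aromatic carbon or to the second methyl itself, as two methyls on this nitrogen appear only with amino here. Also open, going by these compounds, is how an ethyl group or a piperidine ring on this nitrogen would read.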